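Swapping the Isopropylphenyl Arm of Compound 1

A few compounds are considered here, and "the series" means these few. Any claim that something is new, unique, unknown or untested is made for them only; others in the source may bear on it.

Compound 1 `CC(C)c1ccc(-c2nc(SCc3cn(CC(=O)NC(=O)Nc4ccccn4)nn3)nc(Nc3cccc(Cl)c3)c2C#N)cc1` carries a 4-isopropylphenyl group on the shared core and a 3-chlorophenyl on the ring nitrogen. In a functional assay on B16-F10 cells (Mus musculus) for inhibition, read by MTT assay, with a stated time of 72 h (a lower number here means a stronger inhibitor, a higher number a weaker inhibitor), compound 1 gives 1130 nM, the lowest of the three numbers measured. Compound 2 `CC(C)c1ccc(-c2nc(SCc3cn(CC(=O)NC(=O)Nc4ccccn4)nn3)nc(Nc3cccc(C(F)(F)F)c3)c2C#N)cc1` gives 1700 nM, and a 1.5-fold higher number from compound 1 to compound 2 (0.18 log units; within the scatter), so these two cannot be told apart. Compound 3 `CC(C)c1ccc(-c2nc(SCc3cn(CC(=O)NC(=O)Nc4ccccn4)nn3)nc(Nc3ccccc3F)c2C#N)cc1` gives 8380 nM, and a 7.4-fold higher number from compound 1 to compound 3 (0.87 log units; beyond the scatter), while a 4.9-fold higher number from compound 2 to compound 3 (0.69 log units; beyond the scatter).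

Compound 4 `COc1cc(-c2nc(SCc3cn(CC(=O)NC(=O)Nc4ccccn4)nn3)nc(Nc3cccc(Cl)c3)c2C#N)cc(OC)c1OC` differs from compound 1 at a different place: 3,4,5-trimethoxyphenyl in place of 4-isopropylphenyl on an aromatic carbon. Among the measured compounds shown here, every measured step above concerns only the group on the ring nitrogen, so none of them bears on this new change; the numbers for compound 1, compound 2 and compound 3 show only that the anilino group can shift the result modestly, and nothing about the aromatic arm sitting on an aromatic carbon next to the ring nitrogen. For the measured compounds named here, with no directly comparable step in hand, the expectation for compound 4 is a number close to that of compound 1, with a wide band of doubt on either side; a 1.3-fold higher number from compound 1 to compound 4 (0.12 log units; within the scatter) is the estimated step. Compound 4 is therefore expected to give about 1500 nM, within a range from 300 nM to 8000 nM.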

Compound 4, half-maximal inhibitory concentration: 1420 nM
Compound 4: middle estimate off by 1.1-fold (0.02 log units), on the high side; the range from low to high includes it.
By their numbers in this assay, from the lowest: compounds 1, 4 and 2 (each within the scatter of the next); then compound 3.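

Among the compounds shown here, compounds 1, 2 and 3 vary only the group on the ring nitrogen, so compound 4 gives the first look at a different place: the aromatic carbon next to the ring nitrogen and ortho to a cyano group. In this assay, putting 3,4,5-trimethoxyphenyl in place of 4-isopropylphenyl gives a 1.3-fold higher number from compound 1 to compound 4 (0.10 log units; within the scatter), so the two compounds cannot be told apart, even though the entering group has 12 heavy atoms against 9 and 3 hydrogen-bond acceptors against 0. At this position, then, two quite differently substituted phenyl rings read alike in this cell assay, though no supporting measurement is available to explain that result.

Going by these compounds, these two aromatic arms say little about how far the position can be pushed, and it remains open whether an unsubstituted phenyl, a carboxylic acid on the ring or a basic amine such as a piperazine would read the same. On these data alone, it is also open whether the 3,4,5-trimethoxyphenyl arm would match the 4-isopropylphenyl arm when the ring nitrogen carries 2-fluorophenyl, as in compound 3.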